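Swapping the piperazine cap on a chalcone: nitrophenyl to methoxyphenylsulfonyl

The compounds below may be only part of what the source reports. "The series", "measured", "known", "first", "only" and "open" are said of these compounds alone.

Measured compounds:
Compound 1 `O=C(/C=C/c1ccccc1)c1ccc(N2CCN(c3ccc([N+](=O)[O-])cc3)CC2)cc1` gives 55.4%.
Compound 2 `COc1ccccc1N1CCN(c2ccc(C(=O)/C=C/c3ccc(Cl)cc3)cc2)CC1` gives 6.13%.
Compound 3 `O=C(/C=C/c1ccccc1)c1ccc(N2CCN(S(=O)(=O)c3ccc(Cl)cc3)CC2)cc1` gives 46.8%.

These three compounds were tested in a functional assay on the whole organism (strain Kunming) for inhibition, with Mus musculus as the target, with a stated time of 1 h, at a dose of 40 mg/kg by the oral route; a higher number here means more inhibition at the dose given (going by the name of the read-out), a lower number less inhibition. Compound 1 stands highest of the three numbers; compound 3 lies nearest to it, and the gap between them is within the usual scatter, while compound 2 lies far lower, beyond the scatter. Going by the values given here, the only measured single-site step is a number 8.6 percentage points lower from compound 1 to compound 3 (within the scatter), so exchanging the group on the ring nitrogen for an aryl sulfonyl left the read-out essentially unchanged.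

Compound 4 `COc1ccc(S(=O)(=O)N2CCN(c3ccc(C(=O)/C=C/c4ccccc4)cc3)CC2)cc1` has not yet been measured. It differs from compound 1 in one place: (4-methoxyphenyl)sulfonyl in place of 4-nitrophenyl on an amine nitrogen in a ring. Among the compounds with values here, this change is of the same kind as the one from compound 1 to compound 3, and that step was within the scatter. The expectation for compound 4 is therefore a step of a number 8.4 percentage points lower from compound 1 to compound 4 (within the scatter), that is, no movement beyond the scatter. The estimated value for compound 4 in this assay is 47%, with a range from 27% to 65%.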

Compound 4, a percentage reported as inhibition, in the whole organism at one dose (the size of the read-out at that dose, not a potency): 45.2%
Beside the measured number, compound 4's estimate is 1.8 percentage points above it; low and high end bracket the measured number.
By their numbers in this assay, from the lowest: compound 2; then compounds 4, 3 and 1 (each within the scatter of the next, the first and the last beyond it).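

In this assay, going by these compounds alone, placing (4-methoxyphenyl)sulfonyl in place of 4-nitrophenyl on the ring nitrogen gives a number 10.2 percentage points lower from compound 1 to compound 4 (beyond the scatter) and is the first change at this position to pass the usual scatter, although only modestly. On the aromatic ring of the sulfonyl group, methoxy in place of chloro gives a number 1.6 percentage points lower from compound 3 to compound 4 (within the scatter) and so these two groups cannot be told apart in this read-out. No measurement is available to explain either step.

The compounds shown leave open whether an aromatic ring on the sulfonyl group is needed at all, which a methylsulfonyl group on the same nitrogen would test. From the compounds shown here alone, it also remains open how an amine or a carboxylic acid on that aromatic ring would compare with chloro and methoxy.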